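A few compounds are considered here, and "the series" means these few. Any claim that something is new, unique, unknown or untested is made for them only; others in the source may bear on it.

Values in a functional assay on C6 cells (Rattus norvegicus) for cytotoxicity, read by MTT assay, with a stated time of 24 h (on this read-out higher numbers stand for weaker inhibition and lower numbers for stronger inhibition), for the measured compounds:

Compound 1 `O=C(CSc1ncccn1)N/N=c1/scc(-c2ccccc2)n1-c1ccccc1`: "not determined" (no result reported)
Compound 2 `O=C(CSc1ncccn1)N/N=c1/scc(-c2ccc(Br)cc2)n1-c1ccccc1`: > 200 ug/mL
Compound 3 `COc1ccc(-c2cs/c(=N/NC(=O)CSc3ncccn3)n2-c2ccccc2)cc1`: 102 ug/mL

Compound 1, the parent of the pair followed here, has no single number in this assay; its result was not reported. Of the three entries shown, one is a limit rather than a number (the limit of > 200 ug/mL in this assay, at which 1 of the 3 values shown sits). The value of compound 2 is such a limit of the assay and not a measured concentration. Within the data shown here, compound 3 is the only compound of the three with a numerical result. Among the measured compounds shown here, the one measured step, an at least 1.9-fold lower number from compound 2 to compound 3 (0.29 log units; that floor lies within the scatter), concerns a substituent on the aromatic ring and its floor lies within the usual scatter, so it anchors no real change in this assay.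

Compound 4 `Cn1nnnc1SCC(=O)N/N=c1/scc(-c2ccccc2)n1-c1ccccc1` differs from compound 1 by 1-methyl-1H-tetrazol-5-yl in place of pyrimidin-2-yl on a sulfur. For the measured compounds named here, no measured pair varies this sulfur-attached heterocycle, so the step from compound 1 to compound 4 has no measured counterpart to lean on, and compound 1 itself carries no number to step from. The expectation for compound 4 is therefore taken from the level at which the measured compounds sit, with no directional shift assumed. Compound 4 is estimated at 150 ug/mL, with a range from 60 ug/mL to 300 ug/mL, and a substantial chance that only a limit is reported.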

Compound 4, half-maximal inhibitory concentration: 67.7 ug/mL
Estimate against measurement, compound 4: 2.2-fold (0.35 log units) above; the measured number falls inside the stated range.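

Among these compounds, compound 1 has no reported result in this assay, so no step to compound 4 can be read, and compound 4 stands without a measured partner. Compound 2 gives only a limit: the limit of > 200 ug/mL in this assay, at which 1 of the 4 values shown sits.

The compounds shown leave open how 1-methyl-1H-tetrazol-5-yl in place of pyrimidin-2-yl on the sulfur alters this read-out.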